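Five-membered ring replacements on the benzylic aryl position

The compounds below may be only part of what the source reports. "The series", "measured", "known", "first", "only" and "open" are said of these compounds alone.

Compound 3 `Cc1cc(C)c(NC(=O)N(Cc2ccc(-c3ccn(C)n3)cc2)C2CCCCCC2)c(C)c1` has the highest of the three numbers in an assay on microsomes from intestine for inhibition of acyl-CoA:cholesterol acyltransferase (Oryctolagus cuniculus) (on this read-out lower numbers stand for stronger inhibition and higher numbers for weaker inhibition), giving 44 nM; compound 2 `Cc1cc(C)c(NC(=O)N(Cc2ccc(-c3ccccn3)cc2)C2CCCCCC2)c(C)c1` gives 33 nM and compound 1 `Cc1cc(C)c(NC(=O)N(Cc2ccc(-c3cccs3)cc2)C2CCCCCC2)c(C)c1` gives 22 nM, with a 1.3-fold higher number from compound 2 to compound 3 (0.12 log units; within the scatter) and a 2.0-fold higher number from compound 1 to compound 3 (0.30 log units; within the scatter) both within the scatter, as is a 1.5-fold higher number from compound 1 to compound 2 (0.18 log units; within the scatter). Compound 4 `Cc1cc(C)c(NC(=O)N(Cc2ccc(-n3nccn3)cc2)C2CCCCCC2)c(C)c1` differs from compound 3 by 2H-1,2,3-triazol-2-yl in place of 1-methyl-1H-pyrazol-3-yl on an aromatic carbon. All three measured steps exchange one aromatic ring for another at the same place and none reached beyond the scatter, so the step of a 1.0-fold higher number from compound 3 to compound 4 (0.01 log units; within the scatter) is expected to be small as well, with no sure direction. Compound 4 is therefore estimated at 45 nM in this assay, with a range from 20 nM to 100 nM.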

Compound 4, half-maximal inhibitory concentration: 130 nM
Compound 4: the middle estimate sits 2.9-fold (0.46 log units) below what was measured, outside the stated range (above it).
By their numbers in this assay, from the lowest: compounds 1, 2 and 3 (each within the scatter of the next); then compound 4.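

In this assay, going by these compounds alone, this position proves not indifferent to the ring it carries: 2H-1,2,3-triazol-2-yl gives the first steps beyond the scatter, with a 3.0-fold higher number from compound 3 to compound 4 (0.47 log units; beyond the scatter), a 3.9-fold higher number from compound 2 to compound 4 (0.60 log units; beyond the scatter) and a 5.9-fold higher number from compound 1 to compound 4 (0.77 log units; beyond the scatter). Ring size alone does not set this apart, since the five-membered 1-methyl-1H-pyrazol-3-yl stays within the scatter of the other two groups. Nothing available bears on the reason for this shift.

Open, from the compounds shown here alone, is whether the ring nitrogen attachment or the third ring nitrogen matters, which a carbon-linked triazole could separate. Going by these compounds, a plain phenyl ring or an amine at this place also remains open.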